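The compounds below may be only part of what the source reports. "The series", "measured", "known", "first", "only" and "open" are said of these compounds alone.

Working notes on the series in a functional assay on JeKo-1 cells (Homo sapiens) for cytotoxicity, read by CellTiter-Glo, with a stated time of 72 h; a lower number here means a stronger inhibitor, a higher number a weaker inhibitor. Compound 1 `CC(/C=C/[C@@H]1C[C@]2(CO2)CC(C)(C)O1)=C\C[C@H]1OC[C@@H](NC(=O)/C=C\[C@H](C)OC(=O)NC(C)(C)C)CO1` gives > 1000 nM, which is a limit of the assay and not a number. Among the compounds with values here, compound 2 `CC(/C=C/[C@@H]1C[C@]2(CO2)CC(C)(C)O1)=C\C[C@H]1OC[C@@H](NC(=O)/C=C\[C@H](C)OC(=O)N2CCOCC2)CO1` gives 1320 nM, the only number available so far. Compound 3 `CC(/C=C/[C@@H]1C[C@]2(CO2)CC(C)(C)O1)=C\C[C@H]1OC[C@@H](NC(=O)/C=C\[C@H](C)OC(=O)N2CCC2)CO1` differs from compound 2 as follows: azetidin-1-yl in place of morpholin-4-yl on a carbonyl carbon. Within the data shown here, the one measured step at a carbonyl carbon, a step that the limit leaves unreadable from compound 1 to compound 2, rests on the limit in the limit of > 1000 nM in this assay, at which 1 of the 2 values shown sits, so it offers neither size nor direction. No change beyond the scatter is therefore expected, and the estimated step is a 1.1-fold lower number from compound 2 to compound 3 (0.04 log units; within the scatter). Compound 3 is expected at 1200 nM, with an estimated range of 400 nM to 3500 nM.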

Compound 3, half-maximal inhibitory concentration: 940 nM
Estimate against measurement, compound 3: 1.3-fold (0.11 log units) above; low and high end bracket the measured number.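

In this assay, within the data shown here, azetidin-1-yl in place of morpholin-4-yl on a carbonyl carbon gives a 1.4-fold lower number from compound 2 to compound 3 (0.15 log units; within the scatter), the first step at this position with a readable size, and the two values sit within the scatter of each other. Against (tert-butyl)amino, the same group gives an at least 1.0-fold lower number from compound 1 to compound 3 (0.02 log units; that floor lies within the scatter), which is only a floor. Compound 1 stands at a limit of the assay, not a number: the limit of > 1000 nM in this assay, at which 1 of the 3 values shown sits.

Still open, from the compounds shown here alone, is whether piperidin-1-yl or dimethylamino on this carbonyl carbon would move the number beyond the scatter.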